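Swapping methyl for an amino group on the shared core

A few compounds are considered here, and "the series" means these few. Any claim that something is new, unique, unknown or untested is made for them only; others in the source may bear on it.

In a functional assay on HeLa cells (Homo sapiens) for antiproliferative activity, read by MTT assay, with a stated time of 48 h (a lower number here means a stronger inhibitor, a higher number a weaker inhibitor), compound 1 `Cc1nc2ccccc2nc1Oc1ccc(C(=O)N[C@@H](C)C(=O)O)cc1` gives 22300 nM and compound 2 `CC[C@@H](C)[C@H](NC(=O)c1ccc(Oc2nc3ccccc3nc2C)cc1)C(=O)O` gives 33200 nM. Going by the values given here, the only measured step, a 1.5-fold higher number from compound 1 to compound 2 (0.17 log units; within the scatter), lies within the scatter, so compound 2 stands level with compound 1. Compound 3 `CC[C@@H](C)[C@H](NC(=O)c1ccc(Oc2nc3ccccc3nc2NC(C)(C)C)cc1)C(=O)O` has (tert-butyl)amino in place of methyl on an aromatic carbon. The measured step changed a saturated chain carbon, not this aromatic carbon, so it offers little guidance. The tentatively expected step is a 2.2-fold lower number from compound 2 to compound 3 (0.35 log units; beyond the scatter), with its direction uncertain. For compound 3 the estimated value is 15000 nM, within an expected range of 4000 nM to 60000 nM.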

Compound 3, half-maximal inhibitory concentration: 13400 nM
Compound 3: middle estimate off by 1.1-fold (0.05 log units), on the high side, within the range that was stated.
By their numbers in this assay, from the lowest: compounds 3, 1 and 2 (each within the scatter of the next, the first and the last beyond it).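

In this assay the change on this aromatic carbon gives a 2.5-fold lower number from compound 2 to compound 3 (0.39 log units; beyond the scatter) and so, unlike the earlier step on the saturated chain carbon, lies beyond the scatter. This position therefore accepts (tert-butyl)amino in place of methyl, and the number falls modestly rather than rises. No measurement of any property is available to explain this step. The compounds shown leave open whether the amine nitrogen or the tert-butyl part accounts for the step. A plain amino group or a methylamino group at this position would help to separate the two.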